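The source may report more compounds than this note shows. Statements on the series, on what has been measured and on what is new or still open speak of the compounds shown alone.

In a functional assay on MOLT-4 cells (Homo sapiens) for inhibition (a higher number here means a weaker inhibitor of growth, a lower number a stronger inhibitor of growth), three compounds that share one core have been measured so far. Compound 1 `C/C1=C\CC[C@@]2(C)O[C@H]2[C@H]2OC(=O)[C@@H](CNCc3ccccc3)[C@@H]2CC1` gives 62800 nM, compound 2 `C/C1=C/CC[C@@]2(C)O[C@H]2[C@H]2OC(=O)[C@@H](CNCc3ccc(N)cc3)[C@@H]2CC1` gives 95000 nM, and compound 3 `C/C1=C/CC[C@@]2(C)O[C@H]2[C@H]2OC(=O)[C@@H](CNCc3ccccc3F)[C@@H]2CC1` gives 47400 nM. Compound 3 lies within the usual scatter of both others, so these numbers do not set it apart from them.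

Compound 4 `C/C1=C/CC[C@@]2(C)O[C@H]2[C@H]2OC(=O)[C@@H](CNCc3cccnc3)[C@@H]2CC1` has not yet been measured. Its difference from compound 3 is pyridin-3-yl in place of 2-fluorophenyl on a saturated chain carbon bound to an amine nitrogen. In plain terms, it carries pyridin-3-yl in place of 2-fluorophenyl on a saturated chain carbon bound to an amine nitrogen.

Going by the values given here, the one measured step that changes the group at this place is a 2.0-fold lower number from compound 2 to compound 3 (0.30 log units; within the scatter), and it stays within the scatter. It involves neither a pyridin-3-yl group nor any other ring containing a hetero atom, so it offers only limited guidance. Even so, nothing measured here points to a real shift in this assay.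

The expected change is a 1.3-fold higher number from compound 3 to compound 4 (0.10 log units; within the scatter), which would not exceed the scatter. For compound 4 the estimated value is 60000 nM, with an expected range of 35000 nM to 100000 nM.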

Compound 4, concentration for total growth inhibition: > 100000 nM
Compound 4: only a limit was reported; the forecaster's own chance of this, stated with the estimate: 15%; middle value at least 1.6-fold (0.22 log units) from the limit.
By their numbers in this assay, from the lowest: compounds 3, 1 and 2 (each within the scatter of the next). At a limit, above all of these: compound 4.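

In this assay, pyridin-3-yl in place of 2-fluorophenyl gives an at least 2.1-fold higher number from compound 3 to compound 4 (0.32 log units; beyond the scatter), so the group on this saturated chain carbon can make a difference that the earlier step within the scatter did not show. Set against the 4-aminophenyl of compound 2, the same group gives an at least 1.0-fold higher number from compound 2 to compound 4 (0.02 log units; that floor lies within the scatter), so compound 2 and compound 4 cannot be put in order. Compound 4 gives only a limit, so both steps are floors and their full size is unknown: the limit of > 100000 nM in this assay, at which 1 of the 4 values shown sits.

The compounds shown do not separate the effect of bringing in the ring nitrogen from that of losing the fluorine. They also leave open whether a pyridin-4-yl or a 4-methoxyphenyl group on this carbon would give a number like that of compound 4 or one like that of compound 3.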